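Adding a Methyl to the Ring Nitrogen of Compound 2

The source may report more compounds than this note shows. Statements on the series, on what has been measured and on what is new or still open speak of the compounds shown alone.

Three compounds sharing one core were tested in an assay on membranes from HeLa cells for displacement of a labelled ligand from adenosine receptor A3 (Homo sapiens), read by scintillation counting, with a stated time of 180 min, tested at 1 uM; on this read-out higher numbers stand for more inhibition at the one concentration tested (going by the name of the read-out) and lower numbers for less inhibition. Compound 1 `CC1=C(C(=O)OCc2ccccc2)C(c2ccco2)NC(=O)N1` gives 3%, compound 2 `CC1=C(C(=O)OCc2ccccc2)C(c2cccs2)NC(=O)N1` gives 8%, and compound 3 `CC1=C(C(=O)OCc2ccccc2)C(c2ccsc2)NC(=O)N1` gives 25%. Every measured step swaps the aromatic group on the saturated ring carbon: a number 5 percentage points higher from compound 1 to compound 2 (within the scatter), a number 22 percentage points higher from compound 1 to compound 3 (beyond the scatter) and a number 17 percentage points higher from compound 2 to compound 3 (beyond the scatter). Compound 2 stands second highest of the three numbers, within the scatter of compound 1 and clearly lower than compound 3.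

Compound 4 `CC1=C(C(=O)OCc2ccccc2)C(c2cccs2)NC(=O)N1C` differs from compound 2 in a different place: methyl in place of hydrogen on an amide-type nitrogen in a ring. Within the data shown here, none of the measured steps touches this ring nitrogen, so nothing among the measured compounds shows how such a change shifts the read-out. Among the measured compounds shown here, with no bearing step, the plain expectation is no movement beyond the scatter, and the expected step is no change at the digits printed from compound 2 to compound 4 (within the scatter). For compound 4 the estimated value in this assay is therefore 8%, with an expected range from -6% to 24%.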

Compound 4, a percentage reported as inhibition, at one concentration (the size of the read-out at that concentration, not a potency): 18%
Compound 4: middle estimate off by 10 percentage points, on the low side, within the range that was stated.
By their numbers in this assay, from the lowest: compounds 1, 2, 4 and 3 (each within the scatter of the next, the first and the last beyond it).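

In this assay, among these compounds, methyl in place of hydrogen on the amide-type nitrogen in the ring gives a number 10 percentage points higher from compound 2 to compound 4 (within the scatter), the first reading at this position, since every earlier step changed only the aromatic group on the saturated ring carbon. For this one pair, then, the amide hydrogen can give way to a methyl without the read-out moving beyond the scatter, although each number reports inhibition at a single concentration and is not a potency. No measured information offers an explanation for this result.

On these data alone, whether a longer chain such as ethyl, or a chain ending in an amine or a carboxylic acid, would behave the same way on this nitrogen remains open. So does whether methyl here would give a similar result with the furan-2-yl of compound 1 or the thiophen-3-yl of compound 3.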